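The source may report more compounds than this note shows. Statements on the series, on what has been measured and on what is new or still open speak of the compounds shown alone.

Compound 1 `Cc1c(C(=O)N/N=C\c2cccc(F)c2)oc2cccc(O)c12` reaches only a limit in a functional assay on PC-3 cells (Homo sapiens) for inhibition; on this read-out higher numbers stand for weaker inhibition and lower numbers for stronger inhibition: >= 40000 nM.
Compound 2 `Cc1c(C(=O)N/N=C\c2c(O)cccc2F)oc2cccc(O)c12` gives 8050 nM in this assay.

Within the data shown here, compound 2 holds the only true number in this assay. The other entry, that of compound 1, is a limit (the limit of >= 40000 nM in this assay, at which 1 of the 2 values shown sits). Compound 3 `Cc1c(C(=O)N/N=C\c2ccco2)oc2cccc(O)c12` differs from compound 2 by furan-2-yl in place of 2-fluoro-6-hydroxyphenyl on a carbon with a double bond to nitrogen. Among the measured compounds shown here, the single measured step bears on this change in reverse: an at least 4.9-fold lower number from compound 1 to compound 2 (0.69 log units; beyond the scatter) came with the entry of the 2-fluoro-6-hydroxyphenyl, which compound 3 gives up. A step upward in the number is therefore expected for compound 3, a 3.1-fold higher number from compound 2 to compound 3 (0.49 log units; beyond the scatter), possibly back to the limit. Estimate for compound 3: 25000 nM, within 8000 nM to 60000 nM.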

Compound 3, half-maximal inhibitory concentration: >= 40000 nM
Compound 3 gave a limit, no number; the forecaster's own chance of this, stated with the estimate: 40%; middle value at least 1.6-fold (0.20 log units) away from the limit.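

Furan-2-yl on a carbon with a double bond to nitrogen does not keep the inhibition seen with 2-fluoro-6-hydroxyphenyl in this assay, as the change gives an at least 4.9-fold higher number from compound 2 to compound 3 (0.69 log units; beyond the scatter) on the shared core. The gain of compound 2 therefore now stands against two different replacements, 3-fluorophenyl and furan-2-yl. Compound 3 gives only a limit, as does compound 1, and the step between them cannot be read.

Open, as far as these compounds go, is whether a 2-hydroxyphenyl group alone would keep the inhibition of compound 2. Also open, from the compounds shown here alone, is how a 2-aminophenyl group would read at this place.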